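Notes on the lactam series: anilino in place of isopropoxy

The source may report more compounds than this note shows. Statements on the series, on what has been measured and on what is new or still open speak of the compounds shown alone.

Compound 2 `CC(C)OC1=C(C(=O)c2ccccc2)C(c2ccc(Br)cc2)N(CCCn2ccnc2)C1=O` gives the lowest of the three measured numbers in a functional assay on SAOS-2 cells (Homo sapiens) for antiproliferative activity, read by MTT assay, with a stated time of 72 h (a lower number here means a stronger inhibitor, a higher number a weaker inhibitor), at 23000 nM, although compound 1 stands within the scatter of it. Compound 1 `CCOC1=C(C(=O)c2ccccc2)C(c2ccc(Br)cc2)N(CCCn2ccnc2)C1=O` gives 31700 nM in this assay, and the move a 1.4-fold lower number from compound 1 to compound 2 (0.14 log units; within the scatter) is within the scatter. Compound 3 `NC1=C(C(=O)c2ccccc2)C(c2ccc(Br)cc2)N(CCCn2ccnc2)C1=O` gives 107000 nM; the steps of a 3.4-fold higher number from compound 1 to compound 3 (0.53 log units; beyond the scatter) and a 4.7-fold higher number from compound 2 to compound 3 (0.67 log units; beyond the scatter) both lie beyond the scatter. Compound 4 `O=C(C1=C(Nc2ccccc2)C(=O)N(CCCn2ccnc2)C1c1ccc(Br)cc1)c1ccccc1` carries the change (anilino in place of isopropoxy on a double-bonded ring carbon). Going by the values given here, the only steps that bear on it are the two moves to amino, which each raised the number modestly; anilino, like amino, brings one hydrogen-bond donor. A modest rise beyond the scatter is therefore expected in this assay. Compound 4 is estimated at 45000 nM, with a range of 15000 nM to 130000 nM. The expected step is a 2.0-fold higher number from compound 2 to compound 4 (0.29 log units; within the scatter).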

Compound 4, half-maximal inhibitory concentration: 24400 nM
Beside the measured number, compound 4's estimate is 1.8-fold (0.27 log units) above it; the measured number falls inside the stated range.
By their numbers in this assay, from the lowest: compounds 2, 4 and 1 (each within the scatter of the next); then compound 3.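

At this position on the double-bonded ring carbon, anilino stands level with both alkoxy groups, with a 1.1-fold higher number from compound 2 to compound 4 (0.03 log units; within the scatter) and a 1.3-fold lower number from compound 1 to compound 4 (0.11 log units; within the scatter) both within the scatter, so the hydrogen-bond donor it brings comes with no readable step. The rise seen with amino does not carry over to anilino: phenyl on the amine nitrogen gives a 4.4-fold lower number from compound 3 to compound 4 (0.64 log units; beyond the scatter) and returns the number to the level of the alkoxy compounds. Nothing available accounts for this difference between amino and anilino.

From the compounds shown here alone, it remains open whether a smaller group on the amine nitrogen, such as methyl, would stand with anilino or with amino. Also open, going by these compounds, is how a benzylamino group or a 4-chloroanilino group would read at this carbon.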